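A few compounds are considered here, and "the series" means these few. Any claim that something is new, unique, unknown or untested is made for them only; others in the source may bear on it.

Within the data shown here, compound 1 `CCN1CCc2nc(C#Cc3ccccc3)sc2C1` is the only member of this set with a numeric result: in an assay on HEK293 cells for negative allosteric modulation of metabotropic glutamate receptor 5 (Homo sapiens), read by FLIPR, with a stated time of 1 h (on this read-out higher numbers stand for weaker inhibition and lower numbers for stronger inhibition), compound 1 gives 1200 nM. Compound 2 `C(#Cc1nc2c(s1)CN(C1CCCCC1)CC2)c1ccccc1`, carrying cyclohexyl in place of ethyl on an amine nitrogen in a ring, reaches only a limit of the measurement, and in this assay compound 2 gives > 10000 nM. Compound 3 `O=C(C1CCOCC1)N1CCc2nc(C#Cc3ccccc3)sc2C1`, with (oxan-4-yl)carbonyl in place of ethyl on an amine nitrogen in a ring, likewise stops at a limit, and in this assay compound 3 gives > 10000 nM. The two measured steps away from compound 1 are thus an at least 8.3-fold higher number from compound 1 to compound 2 (0.92 log units; beyond the scatter) and an at least 8.3-fold higher number from compound 1 to compound 3 (0.92 log units; beyond the scatter), while the step that the two limits leave unreadable from compound 2 to compound 3 cannot be read because both compounds sit at the limit of > 10000 nM in this assay, at which 2 of the 3 values shown sit.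

Compound 4 `O=C(C1CCCCO1)N1CCc2nc(C#Cc3ccccc3)sc2C1` differs from compound 1 by (oxan-2-yl)carbonyl in place of ethyl on an amine nitrogen in a ring. This change closely mirrors the one that gave an at least 8.3-fold higher number from compound 1 to compound 3 (0.92 log units; beyond the scatter), so a comparable loss is expected, namely a 13-fold higher number from compound 1 to compound 4 (1.10 log units; beyond the scatter). For compound 4 the estimate in this assay is 15000 nM, in a range from 4000 nM to 40000 nM, and the result is expected most likely to be a limit rather than a number.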

Compound 4, half-maximal inhibitory concentration: > 10000 nM
Compound 4: no number, only a limit (the forecaster's own chance of this, stated with the estimate: 70%); the middle value lies beyond the limit too.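

In this assay, replacing ethyl with (oxan-2-yl)carbonyl on the amine nitrogen in a ring gives an at least 8.3-fold higher number from compound 1 to compound 4 (0.92 log units; beyond the scatter), so a second carbonyl group carrying this ring also yields no number at this position. Moving the attachment from oxan-4-yl to oxan-2-yl on the carbonyl carbon does not recover a number, so the loss seen with compound 3 is not confined to one point of attachment. The steps from compound 3 to compound 4 and from compound 2 to compound 4 cannot be read because both ends of each step sit at a limit: the limit of > 10000 nM in this assay, at which 3 of the 4 values shown sit.

From the compounds shown here alone, how far compound 2, compound 3 and compound 4 lie beyond that limit remains open. Going by these compounds, it is also open whether methyl, or acetyl with its much smaller group on the carbonyl, would give a number at this nitrogen.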